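Methyl to ethyl on the carboxamide of a kinase-type scaffold

The compounds below may be only part of what the source reports. "The series", "measured", "known", "first", "only" and "open" are said of these compounds alone.

Measured so far:
compound 1 `CNC(=O)c1cc(Oc2ccc(NC(=O)c3cc4cccnc4n(-c4ccc(F)cc4)c3=O)cc2)ccn1` — 210 nM in a functional assay on NCI-H460 cells (Homo sapiens) for antiproliferative activity, read by MTT assay, with a stated time of 72 h; on this read-out higher numbers stand for weaker inhibition and lower numbers for stronger inhibition
compound 2 `CNC(=O)c1cc(Oc2ccc(NC(=O)c3cc4cccnc4n(-c4ccc(Br)cc4F)c3=O)cc2)ccn1` — "not determined" (no result reported) in this assay

Going by the values given here, compound 1 is the only compound with a number, so it stands alone; compound 2 shares the core but gives nothing to compare. Compound 3 `CCNC(=O)c1cc(Oc2ccc(NC(=O)c3cc4cccnc4n(-c4ccc(F)cc4)c3=O)cc2)ccn1` differs from compound 1 by methyl in place of hydrogen on a saturated chain carbon bound to an amide-type nitrogen. Among the compounds with values here, no step between measured compounds shows how such a change behaves here, so nothing beyond the usual scatter is expected, perhaps a slight loss. Compound 3 is therefore estimated at 300 nM, with a range from 100 nM to 900 nM, a step of a 1.4-fold higher number from compound 1 to compound 3 (0.15 log units; within the scatter) that is expected to stay within the scatter.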

Compound 3, half-maximal inhibitory concentration: 220 nM
The estimate for compound 3 lay 1.4-fold (0.13 log units) above the measured number; the measured number falls inside the stated range.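

In this assay, going by these compounds alone, going from methylcarbamoyl to ethylcarbamoyl gives a 1.0-fold higher number from compound 1 to compound 3 (0.02 log units; within the scatter), the first step that can be read at this position. It shows that a methyl in place of hydrogen on the saturated chain carbon bound to the amide-type nitrogen is tolerated here, since the two numbers lie within the scatter of each other. Nothing measured on hand explains this result.

One step says little about larger changes at this position. A propyl chain, a cyclopropyl ring or a chain ending in an amine could still give a quite different number.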